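Triazole substituent changes on a shared ascorbate-derived core

A few compounds are considered here, and "the series" means these few. Any claim that something is new, unique, unknown or untested is made for them only; others in the source may bear on it.

Measured so far:
- compound 1, `O=C1O[C@H]([C@@H](O)Cn2cc(-c3ccc(Br)cc3)nn2)C(OCc2ccccc2)=C1OCc1ccccc1`: 9420 nM
- compound 2, `CCCCc1cn(C[C@H](O)[C@H]2OC(=O)C(OCc3ccccc3)=C2OCc2ccccc2)nn1`: 10400 nM
- compound 3, `CCCCCCCCCCc1cn(C[C@H](O)[C@H]2OC(=O)C(OCc3ccccc3)=C2OCc2ccccc2)nn1`: 28800 nM

In a functional assay on HCT-116 cells (Homo sapiens) for antiproliferative activity, read by MTT assay, with a stated time of 72 h (a lower number here means a stronger inhibitor, a higher number a weaker inhibitor), compound 1 gives the lowest of the three numbers. The gap to compound 2 is small: a 1.1-fold higher number from compound 1 to compound 2 (0.04 log units; within the scatter), so the two are not separable. Compound 3 lies further off: a 3.1-fold higher number from compound 1 to compound 3 (0.49 log units; beyond the scatter), and the chain-lengthening step a 2.8-fold higher number from compound 2 to compound 3 (0.44 log units; beyond the scatter) agrees with that. Within this set, then, swapping the 4-bromophenyl for a butyl changes nothing resolvable, while the longer decyl costs a modest amount.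

Compound 4, `Cc1ccc(S(=O)(=O)NCc2cn(C[C@H](O)[C@H]3OC(=O)C(OCc4ccccc4)=C3OCc3ccccc3)nn2)cc1`, is not yet measured. It differs from compound 1 as follows: (((4-methylphenyl)sulfonyl)amino)methyl in place of 4-bromophenyl on an aromatic carbon. Among the compounds with values here, no measured step puts a sulfonamide-bearing substituent in this position, so the only guidance is that the shared core tolerates a range of groups here with at most modest movement in this assay. A step no larger than that seen for compound 3 is expected, with a slight lean toward a higher number: a 1.6-fold higher number from compound 1 to compound 4 (0.20 log units; within the scatter). For compound 4 the expected value in this assay is 15000 nM, within 6000 nM to 40000 nM.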

Compound 4, half-maximal inhibitory concentration: 13100 nM
For compound 4 the middle estimate is 1.1-fold (0.06 log units) above the measured one, and the stated range covers the measured number.
By their numbers in this assay, from the lowest: compounds 1, 2 and 4 (each within the scatter of the next); then compound 3.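

In this assay, (((4-methylphenyl)sulfonyl)amino)methyl on this aromatic carbon cannot be separated from 4-bromophenyl (a 1.4-fold higher number from compound 1 to compound 4 (0.14 log units; within the scatter)) or from the butyl of compound 2 (a 1.3-fold higher number from compound 2 to compound 4 (0.10 log units; within the scatter)). Within the data shown here, the position therefore accepts a substituent with a hydrogen-bond donor and hydrogen-bond acceptors, which the earlier compounds lack, with no resolvable movement from those two compounds. Compound 3 remains the one set apart, as the step to the sulfonamide-bearing substituent also shows (a 2.2-fold lower number from compound 3 to compound 4 (0.34 log units; beyond the scatter)), and no measurement at hand explains any of these numbers.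

Open, from the compounds shown here alone, is whether a primary amine or a carboxylic acid at this carbon would stay with compounds 1, 2 and 4. Also open, going by these compounds, is where between butyl and decyl an unbranched chain such as hexyl or octyl would fall.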